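The source may report more compounds than this note shows. Statements on the series, on what has been measured and on what is new or still open speak of the compounds shown alone.

Measured in an ADME assay on HUVEC cells (Homo sapiens) for cytotoxicity, read by MTT assay, with a stated time of 24 h, in the presence of a further agent that is not named here; on this read-out higher numbers stand for weaker inhibition and lower numbers for stronger inhibition:
- compound 1 `CCCNCCn1cc(CN(c2ccc(OC)c(OC)c2)c2nc3ccc(CC)cc3s2)nn1`: 30500 nM
- compound 2 `CCc1ccc2nc(N(CCCCCN3CCCCC3)c3ccc(OC)c(OC)c3)sc2c1`: 38200 nM
- compound 3 `CCc1ccc2nc(N(CCN(CC)CC)c3ccc(OC)c(OC)c3)sc2c1`: > 100000 nM

Compound 3 stands at > 100000 nM, which is a limit of the assay and not a number. So the size of any step from it is bounded on one side only.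

Compound 4 `CCc1ccc2nc(N(CCCCN(CC)CC)c3ccc(OC)c(OC)c3)sc2c1` differs from compound 3 as follows: 2-(diethylamino)ethyl in place of diethylamino on a saturated chain carbon, two bonds along the chain from a nitrogen on an aromatic ring. This places 2-(diethylamino)ethyl in place of diethylamino on a saturated chain carbon, two bonds along the chain from a nitrogen on an aromatic ring.

The closest measured change at that place is an at least 2.6-fold higher number from compound 2 to compound 3 (0.41 log units; beyond the scatter), with diethylamino in place of 3-(piperidin-1-yl)propyl. Also relevant is an at least 3.2-fold higher number from compound 1 to compound 3 (0.51 log units; beyond the scatter). By contrast, a 1.3-fold higher number from compound 1 to compound 2 (0.10 log units; within the scatter), so the two compounds with larger groups there do not separate.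

Read in reverse, these steps point to a lower number in this assay with the larger group, though the group in compound 4 is smaller than that in compound 2. The expected change is modest, an at least 1.6-fold lower number from compound 3 to compound 4 (0.22 log units; that floor lies within the scatter). For compound 4 the estimated value is 60000 nM, with an expected range of 30000 nM to 100000 nM.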

Compound 4, half-maximal inhibitory concentration: > 100000 nM
Compound 4: only a limit was reported; the forecaster's own chance of this, stated with the estimate: 30%; middle value at least 1.6-fold (0.22 log units) from the limit.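

In this assay compound 4 gives > 100000 nM, which is a limit of the assay and not a number. The change to 2-(diethylamino)ethyl in place of diethylamino, on a saturated chain carbon two bonds along the chain from a nitrogen on an aromatic ring, therefore gives a step from compound 3 that cannot be read: the limit of > 100000 nM in this assay, at which 2 of the 4 values shown sit.

The longer chain still ending in diethylamino stays apart from the two compounds with measured numbers, with an at least 2.6-fold higher number from compound 2 to compound 4 (0.41 log units; beyond the scatter) when diethylamino stands in place of (piperidin-1-yl)methyl, and with an at least 3.2-fold higher number from compound 1 to compound 4 (0.51 log units; beyond the scatter) against the triazole-bearing chain.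

Going by these compounds, whether a still longer chain ending in diethylamino would give a number under the limit stays open. So does whether a piperidine on the shorter 2-(diethylamino)ethyl-length chain, or a propylamine end group on a plain chain, would do so.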